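This account rests on a few compounds, and the source may have more. Where it says the series, first, only, none or still open, it means among the compounds named here.

Measured so far:
compound 1 `O=C(Nc1ccccc1)c1c(O)c2cccnc2n(-c2ccccc2)c1=O` gives 4.6%
compound 2 `COc1ccc(NC(=O)c2c(O)c3cccnc3n(-c3ccccc3)c2=O)cc1` gives 0.3%

Both numbers come from a functional assay on the whole organism for inhibition, with Rattus norvegicus as the target, read by paw edema, at a dose of 100 mg/kg by the oral route; on this read-out higher numbers stand for more inhibition at the one dose given (going by the name of the read-out) and lower numbers for less inhibition. For the measured compounds named here, compound 1 carries the larger of the two numbers, but the single step of a number 4.3 percentage points lower from compound 1 to compound 2 (within the scatter) lies within the scatter, so the two compounds cannot be told apart on this read-out; both sit near the bottom of the scale.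

The step under consideration goes from compound 1 to compound 3 `COc1ccc(NC(=O)c2c(O)c3cccnc3n(-c3ccccc3)c2=O)cn1`: 6-methoxypyridin-3-yl in place of phenyl on an amide-type nitrogen. Going by the values given here, the only measured step that bears on it is the one from compound 1 to compound 2, where a methoxy in place of hydrogen on an aromatic carbon gave a number 4.3 percentage points lower from compound 1 to compound 2 (within the scatter). The new change carries that methoxy as well, together with a ring nitrogen for which no comparison exists in the series. On what is known, a step beyond the scatter is not expected in this assay, in either direction.

Compound 3 is therefore estimated at 3%, within 0% to 15%, which means an expected step of a number 1.6 percentage points lower from compound 1 to compound 3 (within the scatter).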

Compound 3, a percentage reported as inhibition, in the whole organism at one dose (the size of the read-out at that dose, not a potency): 13.1%
The estimate for compound 3 lay 10.1 percentage points below the measured number, within the range that was stated.
By their numbers in this assay, from the lowest: compounds 2, 1 and 3 (each within the scatter of the next, the first and the last beyond it).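

In this assay, 6-methoxypyridin-3-yl in place of phenyl on the amide-type nitrogen gives a number 8.5 percentage points higher from compound 1 to compound 3 (within the scatter), so this change does not separate compound 3 from compound 1 on this read-out. For the compounds shown here, the comparison with the methoxy group present on both rings is clearer: 6-methoxypyridin-3-yl in place of 4-methoxyphenyl gives a number 12.8 percentage points higher from compound 2 to compound 3 (beyond the scatter), the first step at this position to pass the scatter, although a modest one. This shows that the group on the amide-type nitrogen can shift the number in this assay when the aromatic ring itself is changed, but nothing available accounts for the shift.

On these data alone, it remains open whether the ring nitrogen alone can carry this step, which a plain pyridin-3-yl group on the same nitrogen would test, and whether the methoxy can be replaced by an amine or a carboxylic acid without losing it. As far as these compounds go, with compound 3 at 13.1% at a single dose, it is also open whether any group at this position can lift the series clearly off the low end of the scale.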